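Methoxy for Methyl: Expected Cytotoxicity of Compound 4

This account rests on a few compounds, and the source may have more. Where it says the series, first, only, none or still open, it means among the compounds named here.

Compound 1 `CCS(=O)(=O)Nc1ccc(NC(=O)c2ccc(Cl)cc2)cc1C` gives 125000 nM in an ADME assay on HEK293 cells (Homo sapiens) for cytotoxicity, read by MTT assay, with a stated time of 48 h; on this read-out lower numbers stand for stronger inhibition and higher numbers for weaker inhibition.
Compound 2 `CCS(=O)(=O)Nc1ccc(NC(=O)c2ccc(C#N)cc2)cc1C` gives only a limit of > 250000 nM.
Compound 3 `Cc1cc(NC(=O)c2ccc(Cl)cc2)ccc1NS(=O)(=O)C(F)(F)F` gives 201000 nM.

Among the two numbers, compound 1 holds the lowest; the step of a 1.6-fold higher number from compound 1 to compound 3 (0.21 log units; within the scatter) lies within the scatter, and the step of an at least 2.0-fold higher number from compound 1 to compound 2 (0.30 log units; that floor lies within the scatter) rests on (the limit of > 250000 nM in this assay, at which 1 of the 3 values shown sits). The change to compound 4 `CCS(=O)(=O)Nc1ccc(NC(=O)c2ccc(Cl)cc2)cc1OC` is methoxy in place of methyl on an aromatic carbon. Neither measured step alters this place on the ring: one swaps the group on the far aromatic ring, the other the group on the sulfonyl sulfur, and both were small. Going by the values given here, no measured step therefore bears directly on the new change, and a step beyond the scatter is not expected. Compound 4 is estimated at 150000 nM, with a range of 70000 nM to 300000 nM, meaning an expected step of a 1.2-fold higher number from compound 1 to compound 4 (0.08 log units; within the scatter).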

Compound 4, half-maximal inhibitory concentration: > 250000 nM
Compound 4: only a limit was reported; the forecaster's own chance of this, stated with the estimate: 25%; at least 1.6-fold (0.22 log units) between middle value and limit.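

Methoxy in place of methyl, ortho to a (ethylsulfonyl)amino group, is the first change shown at this place on the ring, and in this assay it gives an at least 2.0-fold higher number from compound 1 to compound 4 (0.30 log units; that floor lies within the scatter). Compound 4 is reported only as a limit, so this step is a floor and shows no move beyond the scatter. Compound 4 joins compound 2 as a second limit: the limit of > 250000 nM in this assay, at which 2 of the 4 values shown sit.

The compounds shown leave open how far compound 4 truly lies from compound 1. They also leave open how a hydroxyl, an amine or an ethoxy group at this place would read in this assay.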